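Compound 2: difluoropropyl in place of methylsulfanyl

A few compounds are considered here, and "the series" means these few. Any claim that something is new, unique, unknown or untested is made for them only; others in the source may bear on it.

Measured in an ADME assay on a cell-free system (plasma, Homo sapiens) for protein binding:
- compound 1 `Cc1cc(Nc2ccc(C(F)(F)F)cc2)n2nc(CCO)nc2n1`: 67%
- compound 2 `CSc1nc2nc(C)cc(Nc3ccc(S(F)(F)(F)(F)F)cc3)n2n1`: 97.7%
- compound 3 `CSc1nc2nc(C)cc(Nc3ccc(C(F)(F)F)cc3)n2n1`: 91.8%

Compound 2, at 97.7%, has the lowest unbound fraction of the three. Compound 4 `CCC(F)(F)c1nc2nc(C)cc(Nc3ccc(S(F)(F)(F)(F)F)cc3)n2n1` differs from it as follows: 1,1-difluoropropyl in place of methylsulfanyl on an aromatic carbon. Methylsulfanyl in place of 2-hydroxyethyl gave a 4.0-fold lower unbound fraction from compound 1 to compound 3 (0.60 log units; beyond the scatter). Trifluoromethyl in place of pentafluorosulfanyl gave a 3.6-fold higher unbound fraction from compound 2 to compound 3 (0.55 log units; beyond the scatter). Both steps were modest, and neither measures 1,1-difluoropropyl itself. Only a slight fall in unbound fraction, or none beyond the scatter, is therefore expected in this assay. The estimated change is a 1.2-fold lower unbound fraction from compound 2 to compound 4 (0.06 log units; within the scatter). For compound 4 the expected value is 98%, with an estimated range of 95.5% to 99.3%.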

Compound 4, plasma protein binding: 97.7%
The estimate for compound 4 lay 1.2-fold (0.06 log units) (unbound fraction) below the measured number; measured number inside the range.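

On this position, in this assay, 1,1-difluoropropyl in place of methylsulfanyl gives no change at the digits printed from compound 2 to compound 4 (within the scatter). The position therefore takes a chain with more heavy atoms and no ring without a shift in binding beyond the scatter, whereas a 4.0-fold lower unbound fraction from compound 1 to compound 3 (0.60 log units; beyond the scatter) marked a clear step at the same place between 2-hydroxyethyl and methylsulfanyl. No measurement at hand gives a reason for this.

Open, on these data alone, is whether an amine or a carboxylic acid at this position would free more compound in this assay. Also open, as far as these compounds go, is whether 1,1-difluoropropyl would behave alike with trifluoromethyl in place of pentafluorosulfanyl.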